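Working notes on a three-compound series, one assay

The compounds below may be only part of what the source reports. "The series", "measured", "known", "first", "only" and "open" are said of these compounds alone.

Compound 1 `CCOc1cccc2cc(-c3ccc(OC)c(OC)c3)c(=O)oc12` gives only a limit in an assay on CHO cells for displacement of a labelled ligand from adenosine receptor A2b (Homo sapiens), read by radioligand binding (a higher number here means a weaker inhibitor, a lower number a stronger inhibitor), > 30000 nM.
Compound 2 `CCOc1cccc2cc(-c3cc(OC)c(OC)c(OC)c3)c(=O)oc12` likewise gives only a limit, > 30000 nM.

The step that the two limits leave unreadable from compound 1 to compound 2 is not readable, since (the limit of > 30000 nM in this assay, at which 2 of the 2 values shown sit). Compound 2 therefore stands at the limit, with no number of its own. Compound 3 `COc1cc(-c2cc3cccc(C)c3oc2=O)cc(OC)c1OC` differs from compound 2 by methyl in place of ethoxy on an aromatic carbon. No measured step bears on this change, and the single step shown is itself unreadable, so no direction beyond the scatter is expected in this assay. Compound 3 is estimated at 40000 nM, range 10000 nM to 150000 nM, most likely again a limit. The step that the limit leaves unreadable from compound 2 to compound 3 is thus expected to be flat.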

Compound 3, inhibition constant: > 30000 nM
Compound 3 gave a limit, no number; the forecaster's own chance of this, stated with the estimate: 85%; the middle value does not contradict the limit.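

The step from compound 2 to compound 3 cannot be read, because both give only a limit, with no number of their own: the limit of > 30000 nM in this assay, at which 3 of the 3 values shown sit.

From the compounds shown here alone, whether any compound on the shared core gives a number in this assay stays open.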